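The compounds below may be only part of what the source reports. "The series", "measured", "known", "first", "only" and "open" are said of these compounds alone.

Of the compounds shown here, two have been measured in a functional assay (aorta) with Oryctolagus cuniculus as the target; on this read-out lower numbers stand for stronger inhibition and higher numbers for weaker inhibition. Compound 1, with the structure `OCc1ccc(-c2nn(Cc3ccccc3F)c3ccccc23)o1`, gives 4900 nM; 4900 nM (2 entries) in this assay. Going by the values given here, compound 2, with the structure `CC(C)c1cnc(-c2nn(Cc3ccccc3F)c3ncccc23)nc1N`, gives 207000 nM in this assay, the only number recorded for it; a further entry for compound 2 exists without a single number. Among the compounds with values here, no single-site step connects compound 1 and compound 2, so their two values can only be set side by side as they stand.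

Compound 3 has the structure `N#Cc1cnc(-c2nn(Cc3ccccc3F)c3ncccc23)nc1N`. Its difference from compound 2 is cyano in place of isopropyl on an aromatic carbon. Within the data shown here, no measured pair shows what a cyano in place of an isopropyl does here, so there is nothing to lean on but the value of compound 2. The step from compound 2 to compound 3 is expected to be small, with no confident direction, as a 1.4-fold lower number from compound 2 to compound 3 (0.14 log units; within the scatter). Compound 3 is therefore expected to give about 150000 nM in this assay, within a range from 40000 nM to 500000 nM.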

Compound 3, half-maximal inhibitory concentration: 391000 nM
Compound 3: middle estimate off by 2.6-fold (0.42 log units), on the low side; the range from low to high includes it.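

In this assay, placing cyano instead of isopropyl on this aromatic carbon, ortho to an amino group, gives a 1.9-fold higher number from compound 2 to compound 3 (0.28 log units; within the scatter), so this single step does not separate the two groups. The change removes a three-carbon group and brings in a two-atom group with a triple bond and a hydrogen-bond acceptor, yet the read-out stays within the usual scatter of repeated measurements. Nothing available offers an explanation for this result.

This one step leaves open how a methyl, a carboxylic acid or a longer chain would read out on the same carbon. It also leaves open whether any group here can move the number beyond the scatter, and what the neighbouring amino group contributes.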